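The compounds below may be only part of what the source reports. "The series", "measured", "known", "first", "only" and "open" are said of these compounds alone.

Values in an ADME assay on Vero cells (Chlorocebus sabaeus) for cytotoxicity, read by MTT assay, with a stated time of 72 h (on this read-out higher numbers stand for lower toxicity in this test and lower numbers for higher toxicity in this test), so far:
- Compound 1 `COc1c(N2C[C@H]3CCCN(C(=O)Cn4cc(CN5C(=O)C(=O)c6cc(F)ccc65)nn4)[C@H]3C2)c(F)cc2c(=O)c(C(=O)O)cn(C3CC3)c12` gives 16 ug/mL
- Compound 2 `COc1c(N2C[C@H]3CCCN(C(=O)Cn4cc(CN5C(=O)C(=O)c6cccc(F)c65)nn4)[C@H]3C2)c(F)cc2c(=O)c(C(=O)O)cn(C3CC3)c12` gives 32 ug/mL
- Compound 3 `COc1c(N2C[C@H]3CCCN(C(=O)Cn4cc(CN5C(=O)/C(=N/O)c6ccccc65)nn4)[C@H]3C2)c(F)cc2c(=O)c(C(=O)O)cn(C3CC3)c12` gives 32 ug/mL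

Compound 3 stands level with compound 2 at the digits shown and within the scatter of compound 1. The next compound, compound 4 `COc1c(N2C[C@H]3CCCN(C(=O)Cn4cc(CN5C(=O)/C(=N/O)c6cc(F)ccc65)nn4)[C@H]3C2)c(F)cc2c(=O)c(C(=O)O)cn(C3CC3)c12`, differs from it by fluoro in place of hydrogen on an aromatic carbon.

Within the data shown here, no measured step isolates this change. The nearest evidence is a 2.0-fold higher number from compound 1 to compound 2 (0.30 log units; within the scatter), a 2.0-fold higher number from compound 1 to compound 3 (0.30 log units; within the scatter) and no change at the digits printed from compound 2 to compound 3 (within the scatter), all within the scatter. In this assay the expected step is therefore no larger than the scatter, and the estimate is a 1.3-fold lower number from compound 3 to compound 4 (0.12 log units; within the scatter). Compound 4 is expected at 24 ug/mL, with an estimated range of 12 ug/mL to 48 ug/mL.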

Compound 4, half-maximal cytotoxic concentration: 16 ug/mL
For compound 4 the middle estimate is 1.5-fold (0.18 log units) above the measured one, and the stated range covers the measured number.
By their numbers in this assay, from the lowest: compounds 1, 4, 2 and 3 (each within the scatter of the next).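

Read in this assay, fluoro in place of hydrogen, on the aromatic carbon meta to a fused ring and para to a fused ring, gives a 2.0-fold lower number from compound 3 to compound 4 (0.30 log units; within the scatter). Among these compounds, this is the first measured step that isolates this change at this position, and it shows no effect beyond the scatter. Nothing available here bears on the reason for this result.

As far as these compounds go, whether chloro or methoxy on the same aromatic carbon would also stay within the scatter in this assay remains open. So does the outcome of fluoro on the other carbons of this ring.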